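The compounds below may be only part of what the source reports. "The series", "measured", "known", "first", "only" and "open" are said of these compounds alone.

Measured compounds:
compound 1, `Cc1ccc(-c2nc(NO)c3cc(Cl)ccc3n2)cc1`: 12.7 ug/mL
compound 2, `CSc1nc(-c2ccc(C)cc2)nc2ccc(Cl)cc12`: 14.7 ug/mL

In a functional assay on HeLa cells (Homo sapiens) for antiproliferative activity, read by MTT assay, with a stated time of 48 h (on this read-out higher numbers stand for weaker inhibition and lower numbers for stronger inhibition), compound 2 shows the higher of the two numbers, yet the step of a 1.2-fold higher number from compound 1 to compound 2 (0.06 log units; within the scatter) stays within the scatter, so the two compounds cannot be told apart on this read-out. Compound 3, `Cc1ccc(-c2nc(SCc3ccccc3)c3cc(Cl)ccc3n2)cc1`, has not yet been measured. It differs from compound 2 by phenyl in place of hydrogen on a saturated chain carbon bound to a sulfur; cut one bond further out, the change reads methyl to benzyl, methylsulfanyl to benzylsulfanyl. The only measured step exchanges the whole group on the same aromatic carbon of the shared core and hardly moved the number; no measured step enlarges a chain on the sulfur, so nothing shown speaks for a change beyond the scatter. Compound 3 is therefore expected to sit close to compound 2, with an expected step of a 1.2-fold lower number from compound 2 to compound 3 (0.09 log units; within the scatter) in this assay. Compound 3 is estimated at 12 ug/mL, within a range from 5 ug/mL to 30 ug/mL.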

Compound 3, half-maximal inhibitory concentration: 11.3 ug/mL
The estimate for compound 3 lay 1.1-fold (0.03 log units) above the measured number; low and high end bracket the measured number.
By their numbers in this assay, from the lowest: compounds 3, 1 and 2 (each within the scatter of the next).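

Phenyl in place of hydrogen on a saturated chain carbon bound to a sulfur gives a 1.3-fold lower number from compound 2 to compound 3 (0.11 log units; within the scatter) in this assay, so this read-out does not separate benzylsulfanyl from methylsulfanyl, even with six more heavy atoms on the chain. Exchanging the whole group on the aromatic carbon of the shared core gives a 1.1-fold lower number from compound 1 to compound 3 (0.05 log units; within the scatter), so all three groups tried on that carbon remain indistinguishable here. No measurement of any other kind bears on this result, and so nothing can be said about why the number holds steady.

On these data alone, whether an amine or a carboxylic acid on that aromatic carbon, or a longer chain on the sulfur, would move the number stays open. As far as these compounds go, all three compounds also keep the rest of their structure unchanged, so the effect of changes elsewhere remains unknown.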